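A Larger Group on the Sulfonyl Sulfur

The source may report more compounds than this note shows. Statements on the series, on what has been measured and on what is new or still open speak of the compounds shown alone.

Drugs in blood are partly held by plasma proteins, and only the free share can move on to tissues. Within the data shown here, in an ADME assay on a cell-free system (plasma, Homo sapiens) for protein binding (a higher number here means a larger unbound share of the compound, a lower number a smaller unbound share), compound 2 (`CC(C)COc1ccc(-c2cn(C)c3cc(C(=O)NS(C)(=O)=O)c(F)cc23)cn1`) gives 0.008, the only true number available so far. Compound 1 (`CC(C)COc1ncc(-c2cn(C)c3cc(C(=O)NS(=O)(=O)C4CC4)c(F)cc23)cc1Cl`), which also has cyclopropyl on a sulfonyl sulfur, gives < 0.001, a limit of the assay and not a number.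

Compound 3 (`CC(C)COc1ccc(-c2cn(C)c3cc(C(=O)NS(=O)(=O)C4CC4)c(F)cc23)cn1`) has yet to be measured. It differs from compound 2 in one place, with cyclopropyl in place of methyl on a sulfonyl sulfur. Among the measured compounds shown here, no measured pair of compounds shows this change alone, so any forecast is tentative. The expected direction is towards a smaller unbound share, a view that leans on compound 1 and its < 0.001, again a limit. In this assay the estimated change is a 2.0-fold lower number from compound 2 to compound 3 (0.30 log units; within the scatter), a modest step near the edge of the usual scatter between repeats. For compound 3 the expected value is 0.004, with an estimated range of 0.0015 to 0.008.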

Compound 3, unbound fraction: 0.024
The estimate for compound 3 lay 6.0-fold (0.78 log units) below the measured number, outside the stated range (above it).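

In this assay there is now a direct pair for cyclopropyl in place of methyl on a sulfonyl sulfur, and it gives a 3.0-fold higher number from compound 2 to compound 3 (0.48 log units; beyond the scatter), so in this pair the larger group goes with a larger unbound share, not a smaller one. Cyclopropyl is also present on both sides of the step for hydrogen in place of chloro on an aromatic carbon, which gives an at least 24-fold higher number from compound 1 to compound 3 (1.38 log units; beyond the scatter), so the very low reading at the chloro end of that step cannot be tied to cyclopropyl. The value of compound 1 is a limit and not a number, and the step built on it carries that limit: the limit of < 0.001 in this assay, at which 1 of the 3 values shown sits.

On these data alone, each change appears only once, on a single background, so it remains open whether the rise with cyclopropyl would also hold on a core that carries chloro. Also open, as far as these compounds go, is how a longer chain such as n-propyl or an amine such as dimethylamino would compare on the sulfonyl sulfur, and how fluoro or methoxy would compare in the place of chloro.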